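The source may hold more compounds than are shown below. What is called first, only, known or untested is meant among the compounds shown, and "the series" means these compounds.

Measured so far in an assay on isolated protein for inhibition of A disintegrin and metalloproteinase with thrombospondin motifs 5 (Homo sapiens), read by spectrophotometry, with stated times of 10 min and 3 h; a lower number here means a stronger inhibitor, a higher number a weaker inhibitor:
compound 1 `O=C(COc1ccc(C(F)(F)F)cc1)NNC(=S)NCCCCC1CCCCC1`: 540 nM
compound 2 `COc1ccc(OCC(=O)NNC(=S)NCCCCC2CCCCC2)cc1`: a limit only, > 100000 nM

Compound 2 sits at the assay limit (the limit of > 100000 nM in this assay, at which 1 of the 2 values shown sits), so no number is known for it. Among the compounds with values here, compound 1 gives the only number in this assay. Within the data shown here, the single step between the two, an at least 180-fold higher number from compound 1 to compound 2 (2.26 log units; beyond the scatter), is large and runs toward the limit.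

Compound 3 `O=C(COc1ccc([N+](=O)[O-])cc1)NNC(=S)NCCCCC1CCCCC1` differs from compound 2 by nitro in place of methoxy on an aromatic carbon. The step from compound 1 to compound 2 bears on this only indirectly: it shows that exchanging the group on this aromatic carbon can move the number a long way, and that the methoxy compound lies off the scale. With nitro in place of methoxy, a number lower than the limit of compound 2 is expected for compound 3, of a size near an at least 33-fold lower number from compound 2 to compound 3 (1.52 log units; beyond the scatter), though a second limit cannot be ruled out. The estimate for compound 3 in this assay is 3000 nM, within 300 nM to 50000 nM.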

Compound 3, half-maximal inhibitory concentration: 810 nM
For compound 3 the middle estimate is 3.7-fold (0.57 log units) above the measured one; measured number inside the range.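

In this assay, the change from 4-methoxyphenyl to 4-nitrophenyl gives an at least 120-fold lower number from compound 2 to compound 3 (2.09 log units; beyond the scatter), so a number in the range of compound 1 at this aromatic carbon does not depend on trifluoromethyl alone. The two groups are not separated, with a 1.5-fold higher number from compound 1 to compound 3 (0.18 log units; within the scatter), and among the three groups shown methoxy alone stands apart. The size of the step to compound 3 is only a bound, since compound 2 gives a limit and not a number: the limit of > 100000 nM in this assay, at which 1 of the 3 values shown sits.

Open, on these data alone, is whether a chlorine, an amine or a carboxylic acid at this carbon would fall with nitro and trifluoromethyl or with methoxy. Also open, as far as these compounds go, is whether the nitro and trifluoromethyl compounds would keep their numbers with a shorter chain in place of the one in the shared core.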